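This account rests on a few compounds, and the source may have more. Where it says the series, first, only, none or still open, it means among the compounds named here.

Measured compounds:
compound 1 `N=C(N)NCCC[C@H](NC(=O)CN(c1nc(Cl)nc2[nH]cnc12)C1CC1)C(=O)OCc1ccccc1` gives 10.2%
compound 2 `NCCCC[C@H](NC(=O)CN(c1nc(Cl)nc2[nH]cnc12)C1CC1)C(=O)OCc1ccccc1` gives 16.8%
compound 3 `NC(=O)CC[C@H](NC(=O)CN(c1nc(Cl)nc2[nH]cnc12)C1CC1)C(=O)O` gives 17.8%

All three share one core and differ in the amino-acid-derived side arm. In a functional assay on the whole organism (Tail, strain ICR) with Mus musculus as the target, in the tail flick test, with a stated time of 120 min, at a dose of 25 umol/kg by the oral route (on this read-out higher numbers stand for a stronger effect at the one dose given and lower numbers for a weaker effect), compound 3 gives 17.8%, the largest number of the three, yet its gaps to compound 2 and to compound 1 both lie within the usual scatter, so the three compounds cannot be told apart on these data. Within the data shown here, the only step between two measured compounds runs a number 6.6 percentage points higher from compound 1 to compound 2 (within the scatter), and it concerns the side chain, not the acid end of the molecule.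

Compound 4 `NC(=O)CC[C@H](NC(=O)CN(c1nc(Cl)nc2[nH]cnc12)C1CC1)C(=O)OCc1ccccc1` is not yet measured. It differs from compound 3 by benzyl in place of hydrogen on an oxygen next to a carbonyl group. Among the measured compounds shown here, no measured pair shows what this change does; compounds 1 and 2, which carry the benzyl ester, give numbers close to that of compound 3, which carries the free acid, but they also differ from compound 3 in the side chain, so nothing can be read from them about the ester alone. In this assay the expectation for compound 4 is therefore a step of a number 1.8 percentage points lower from compound 3 to compound 4 (within the scatter), which is no step beyond the scatter. The estimate for compound 4 is 16%, expected to fall between 5% and 28%.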

Compound 4, a percentage reported as activity, at one dose (the size of the read-out at that dose, not a potency): 36%
For compound 4 the middle estimate is 20 percentage points below the measured one; measured number above the stated range.
By their numbers in this assay, from the lowest: compounds 1, 2 and 3 (each within the scatter of the next); then compound 4.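

In this assay the change of benzyl in place of hydrogen on an oxygen next to a carbonyl group now has a measured pair of its own (a number 18.2 percentage points higher from compound 3 to compound 4 (beyond the scatter)), so with this side chain the benzyl ester and the free acid can be told apart. Among these compounds, with the benzyl ester held fixed, the side chain also moves the number, which the one earlier step between two esters, lying within the scatter, did not show: carbamoyl in place of 2-aminoethyl gives (a number 19.2 percentage points higher from compound 2 to compound 4 (beyond the scatter)), and another exchange of group on that saturated chain carbon gives (a number 25.8 percentage points higher from compound 1 to compound 4 (beyond the scatter)). Nothing measured here accounts for why either change acts as it does.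

A methyl or an ethyl on the same oxygen would show whether benzyl itself matters or whether any simple ester gives the same result. Going by these compounds, whether the benzyl step holds with other side chains also stays open, as does what a carboxylic acid or a longer chain at the end of the side chain would give.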